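Swapping the terminal ring amine for an open benzylamine

This account rests on a few compounds, and the source may have more. Where it says the series, first, only, none or still open, it means among the compounds named here.

Of the compounds shown here, three sharing one core have been measured in an assay for binding affinity to Melanocortin receptor 4 (Homo sapiens); on this read-out lower numbers stand for stronger inhibition and higher numbers for weaker inhibition. Compound 1 `COc1ccc(Br)cc1CCc1c(F)cccc1C(=O)/N=C(\N)NCCN1CCCC1` gives 190 nM. Compound 2 `COc1ccc(Br)cc1CCc1c(F)cccc1C(=O)/N=C(\N)NCCC1CCCCC1` gives 2600 nM, and the step of a 14-fold higher number from compound 1 to compound 2 (1.14 log units; beyond the scatter) shows how much weaker the binding became when a ring of carbon alone replaced the ring amine. Compound 3 `COc1ccc(Br)cc1CCc1c(F)cccc1C(=O)/N=C(\N)NCCCCN1CCCCC1` gives 0.58 nM, the lowest number of the three and well clear of both others, as a 330-fold lower number from compound 1 to compound 3 (2.52 log units; beyond the scatter) and a 4500-fold lower number from compound 2 to compound 3 (3.65 log units; beyond the scatter) show. Compound 4 `COc1ccc(Br)cc1CCc1c(F)cccc1C(=O)/N=C(\N)NCCCCN(C)Cc1ccccc1` is not yet measured; it differs from compound 3 by benzyl(methyl)amino in place of piperidin-1-yl on a saturated chain carbon, four bonds along the chain from an amine nitrogen. For the measured compounds named here, no measured step keeps an amine in place and alters only the groups it carries, so the comparison rests on what is in hand: the weakening from compound 1 to compound 2 accompanied loss of the amine, whereas compound 4 keeps an amine nitrogen at the same point of the chain. The change is therefore expected to cost little, with a step of a 3.4-fold higher number from compound 3 to compound 4 (0.54 log units; beyond the scatter) expected. Compound 4 is estimated at 2 nM, between 0.3 nM and 15 nM.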

Compound 4, inhibition constant: 5.1 nM
Compound 4: the middle estimate sits 2.6-fold (0.41 log units) below what was measured; the range from low to high includes it.
By their numbers in this assay, from the lowest: compound 3; then compound 4; then compound 1; then compound 2.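

In this assay, this position on a saturated chain carbon, four bonds along the chain from an amine nitrogen, does not need its amine to be tied into a ring: opening the piperidin-1-yl ring to benzyl(methyl)amino gives an 8.8-fold higher number from compound 3 to compound 4 (0.94 log units; beyond the scatter) and costs something real, but only a modest amount. The longer chain ending in an amine also keeps its large lead with this open group, as a 510-fold lower number from compound 2 to compound 4 (2.71 log units; beyond the scatter) and a 37-fold lower number from compound 1 to compound 4 (1.57 log units; beyond the scatter) both show. Nothing available explains why the ring form binds better than the open form.

The compounds shown leave open whether the step comes from the aromatic ring of the benzyl group or from opening the piperidine ring. A small open amine such as dimethylamino, or a morpholine ring, at this same place would help to separate those two readings.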